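A few compounds are considered here, and "the series" means these few. Any claim that something is new, unique, unknown or untested is made for them only; others in the source may bear on it.

Of the compounds shown here, three have numbers so far in a functional assay on MGC-803 cells (Homo sapiens) for cytotoxicity, read by MTT assay, with a stated time of 48 h (on this read-out lower numbers stand for stronger inhibition and higher numbers for weaker inhibition), and they are spread well apart. Compound 1 (`O=C(CSCc1ccco1)N1N=C(c2cc3ccccc3oc2=O)C[C@@H]1c1ccccc1C(F)(F)F`) gives 15700 nM and compound 2 (`O=C(CSc1ccc(Br)cc1)N1N=C(c2cc3ccccc3oc2=O)C[C@@H]1c1ccc(C(F)(F)F)cc1`) gives 10800 nM while compound 3 (`O=C(CSc1ncccn1)N1N=C(c2cc3ccccc3oc2=O)C[C@@H]1c1ccc(C(F)(F)F)cc1`) gives 2890 nM as the lowest number of the three. Compound 4 (`O=C(CSCc1ccco1)N1N=C(c2cc3ccccc3oc2=O)C[C@@H]1c1ccc(C(F)(F)F)cc1`) alters one group of compound 3 ((furan-2-yl)methyl in place of pyrimidin-2-yl on a sulfur) with (furan-2-yl)methyl in place of pyrimidin-2-yl on a sulfur.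

Going by the values given here, the one measured step at this sulfur is a 3.7-fold lower number from compound 2 to compound 3 (0.57 log units; beyond the scatter) with pyrimidin-2-yl replacing 4-bromophenyl. It shows that the group here can move the number beyond the scatter, and that pyrimidin-2-yl sat on the lower side of that step. Among the compounds with values here, compound 1 also carries (furan-2-yl)methyl on a sulfur and gives 15700 nM as the highest number so far, but its structure differs elsewhere, so it is only a loose guide. A modest move toward a higher number is therefore expected in this assay with a 2.9-fold higher number from compound 3 to compound 4 (0.47 log units; beyond the scatter) as the estimated step. The estimate for compound 4 is 8500 nM with an expected range from 3500 nM to 20000 nM for the measurement.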

Compound 4, half-maximal inhibitory concentration: 15200 nM
Compound 4: the middle estimate sits 1.8-fold (0.25 log units) below what was measured; the measured number falls inside the stated range.
By their numbers in this assay, from the lowest: compound 3; then compounds 2, 4 and 1 (each within the scatter of the next).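

In this assay, three groups can now be compared on this sulfur with the rest of the molecule unchanged: a 5.3-fold higher number from compound 3 to compound 4 (0.72 log units; beyond the scatter) separates pyrimidin-2-yl from (furan-2-yl)methyl, while a 1.4-fold higher number from compound 2 to compound 4 (0.15 log units; within the scatter) leaves (furan-2-yl)methyl and 4-bromophenyl indistinguishable, so pyrimidin-2-yl alone stands apart among the three. The change on the saturated ring carbon, a 1.0-fold lower number from compound 1 to compound 4 (0.01 log units; within the scatter), also leaves 4-(trifluoromethyl)phenyl and 2-(trifluoromethyl)phenyl indistinguishable when (furan-2-yl)methyl sits on the sulfur. Nothing available explains why pyrimidin-2-yl stands apart.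

From the compounds shown here alone, what a pyridin-2-yl group, with a single ring nitrogen, or a plain alkyl chain would give on this sulfur stays open, so the role of the two ring nitrogens in pyrimidin-2-yl remains unknown. Also open, going by these compounds, is whether pyrimidin-2-yl would stand apart in the same way with 2-(trifluoromethyl)phenyl on the saturated ring carbon.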